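The source may hold more compounds than are shown below. What is called first, only, known or untested is meant among the compounds shown, and "the series" means these compounds.

Measured compounds:
- compound 1, `COc1cccc(C(O)CCn2nc3c(Br)c(Br)c(Br)c(Br)c3n2)c1`, 121%
- compound 2, `C[C@H](O)CCn1nc2c(Br)c(Br)c(Br)c(Br)c2n1`, 112%

Two compounds on a shared core were measured in a functional assay on MCF7 cells (Homo sapiens) for antiproliferative activity, read by MTT assay, with a stated time of 24 h, tested at 12.5 uM; a lower number here means a stronger effect, a higher number a weaker effect of the compound at the concentration tested. Compound 1 gives 121% in this assay, the highest of the two numbers. Compound 2 gives 112%, a number that lies within the scatter of compound 1, so no order between the two can be read from them. Both numbers sit at or above the untreated level, which means neither compound reduces cell growth at the concentration tested.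

Compound 3, `OC(CCn1nc2c(Br)c(Br)c(Br)c(Br)c2n1)c1ccc(Br)cc1`, has not yet been measured in this assay. It differs from compound 1 in one place: 4-bromophenyl in place of 3-methoxyphenyl on a saturated chain carbon bound to an oxygen on a saturated carbon and a saturated chain carbon. Among the measured compounds shown here, no step between measured compounds is available for this kind of change. Given that compound 1 shows no effect with its 121%, the step from compound 1 to compound 3 is expected to be small, a number 6 percentage points lower from compound 1 to compound 3 (within the scatter), and not beyond the scatter. Compound 3 is therefore estimated at 115%, in a range from 95% to 135%.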

Compound 3, a percentage reported as activity, at one concentration (the size of the read-out at that concentration, not a potency): 82%
For compound 3 the middle estimate is 33 percentage points above the measured one; measured number outside the range, below it.
By their numbers in this assay, from the lowest: compound 3; then compounds 2 and 1 (each within the scatter of the next).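

In this assay, 4-bromophenyl in place of 3-methoxyphenyl on this saturated chain carbon bound to an oxygen gives a number 39 percentage points lower from compound 1 to compound 3 (beyond the scatter), so the aromatic group at this place can clearly shift the read-out. Of the three compounds, only compound 3, at 82%, lies below the untreated level, which shows that the shared core can carry a reduction in cell growth at the concentration tested. Nothing measured here explains why this change has such an effect.

The bromine enters as the methoxy group leaves, so the compounds shown cannot separate the contribution of one from that of the other. On these data alone, how an unsubstituted phenyl or a phenyl carrying an amine would read at this place also remains open.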